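The source may report more compounds than this note shows. Statements on the series, on what has been measured and on what is new or still open speak of the compounds shown alone.

Measured so far in a physicochemical assay for solubility, using the shake flask method, in phosphate buffer, measured as kinetic solubility, with a stated time of 20 h, at pH 6.5; a lower number here means a less soluble compound, a higher number a more soluble compound:

compound 1 `COc1ccc(Nc2cc3[nH]c(-c4cccc(C(F)(F)F)c4)nc3cn2)nc1` — compound 1 gives < 5000 nM, a limit of the assay and not a number.
compound 2 `Fc1ccnc(Nc2cc3[nH]c(-c4ccc(F)c(F)c4)nc3cn2)c1` — compound 2 gives < 5000 nM, likewise a limit.
compound 3 `Fc1ccc(Nc2cc3[nH]c(-c4ccc(F)c(C(F)(F)F)c4)nc3cn2)nc1` — compound 3 gives < 5000 nM, likewise a limit.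

Compound 1 therefore stands at the limit of < 5000 nM in this assay, at which 3 of the 3 values shown sit; no number for it is known, only that it did not reach the limit, and the same holds for compound 2 and compound 3. Among the measured compounds shown here, no pair of measured compounds differs in one place, so no measured step in this assay is available, and nothing in the three measured compounds shows what any single structural change does to solubility here.

Compound 4 `O=C(O)c1ccnc(Nc2cc3[nH]c(-c4cccc(C(F)(F)F)c4)nc3cn2)c1` differs from compound 1 by 4-carboxypyridin-2-yl in place of 5-methoxypyridin-2-yl on a nitrogen on an aromatic ring.

The change exchanges a group with no hydrogen-bond donor for one carrying 1 hydrogen-bond donor and 1 double bond outside aromatic rings. Without a measured step to lean on, the step from compound 1 to compound 4 is expected as an at least 6.0-fold higher number from compound 1 to compound 4 (0.77 log units; beyond the scatter), an increase in solubility rather than none. Compound 4 is estimated at 30000 nM, with a range from 5000 nM to 200000 nM, and there remains a fair chance that compound 4 also returns only a limit.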

Compound 4, solubility: < 5000 nM
Compound 4 was reported as a limit (the forecaster's own chance of this, stated with the estimate: 25%); middle value at least 6.0-fold (0.77 log units) away from the limit.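

In this assay compound 4 gives < 5000 nM, a limit of the assay and not a number. Compound 1 also stands at a limit, so the step between compound 1 and compound 4 cannot be read. As far as these compounds go, whether 4-carboxypyridin-2-yl in place of 5-methoxypyridin-2-yl changes solubility at all remains open.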